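A few compounds are considered here, and "the series" means these few. Any claim that something is new, unique, unknown or untested is made for them only; others in the source may bear on it.

Among the compounds with values here, compound 3 (`CC1(C)C=C(C(=O)NC2CC2)c2cc([N+](=O)[O-])ccc2O1`) stands at 32.4 nM in a functional assay (muscle tissue) with Rattus norvegicus as the target (a lower number here means that less compound is needed, a higher number that more compound is needed for the effect), and so holds the middle place among the three numbers known so far. Compound 2 (`CNC(=O)C1=CC(C)(C)Oc2ccc([N+](=O)[O-])cc21`) lies lower at 10.7 nM and compound 1 (`CNC(=O)C1=CC(C)(C)Oc2ccc(C#N)cc21`) lies higher at 263 nM on the same scale.

Compound 4 (`CC1(C)C=C(C(=O)NCCC#N)c2cc([N+](=O)[O-])ccc2O1`) differs from compound 3 in one place only: 2-cyanoethyl in place of cyclopropyl on an amide-type nitrogen. Within the data shown here, one measured step touches that same nitrogen: a 3.0-fold higher number from compound 2 to compound 3 (0.48 log units; beyond the scatter) (cyclopropyl in place of methyl), and it is modest. The other measured step is a 25-fold lower number from compound 1 to compound 2 (1.39 log units; beyond the scatter) (nitro in place of cyano on an aromatic carbon). It is large, but it does not bear on this change, as compound 4 keeps the nitro group of compound 3.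

Among the measured compounds shown here, no measured compound carries a 2-cyanoethyl group, so the data offer no direct guide to it. Resting on a 3.0-fold higher number from compound 2 to compound 3 (0.48 log units; beyond the scatter) as the only evidence at this nitrogen, a step of similar modest size or smaller is expected in this assay and it may well stay within the scatter. The estimate means a 1.4-fold higher number from compound 3 to compound 4 (0.14 log units; within the scatter) as the expected step. Compound 4 is expected at 45 nM (estimated range 14 nM to 140 nM).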

Compound 4, half-maximal effective concentration: 2.82 nM
Compound 4: the middle estimate sits 16-fold (1.20 log units) above what was measured; measured number below the stated range.
By their numbers in this assay, from the lowest: compound 4; then compound 2; then compound 3; then compound 1.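

At the amide-type nitrogen, the earlier compounds had shown only a modest rise, a 3.0-fold higher number from compound 2 to compound 3 (0.48 log units; beyond the scatter), whereas in this assay the exchange of cyclopropyl for 2-cyanoethyl gives an 11-fold lower number from compound 3 to compound 4 (1.06 log units; beyond the scatter), so this position can shift the number by a large step and can also bring it down. The new group also improves on methyl, the best substituent at this nitrogen until now, with a 3.8-fold lower number from compound 2 to compound 4 (0.58 log units; beyond the scatter), and the order of the three groups does not follow their size, as the methyl of compound 2 lies between the cyclopropyl of compound 3 and the 2-cyanoethyl of compound 4. Nothing measured here gives a reason for these shifts.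

The compounds shown do not tell whether the step belongs to the nitrile or to the open chain that carries it, a question that a plain ethyl group, a 2-hydroxyethyl group or a longer 3-cyanopropyl chain on the same nitrogen could help to settle. They also leave open whether 2-cyanoethyl would give a similar step with cyano in place of nitro on the aromatic carbon.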